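A cyano group added to compound 2

The source may report more compounds than this note shows. Statements on the series, on what has been measured and on what is new or still open speak of the compounds shown alone.

Compound 1 `CC(O)(COc1ccc(C(F)(F)F)cc1)C(=O)Nc1cccc(S(F)(F)(F)(F)F)c1`: 9600 nM
Compound 2 `CC(O)(COc1ccccc1C(F)(F)F)C(=O)Nc1cccc(S(F)(F)(F)(F)F)c1`: 26300 nM

In a functional assay on LNCaP cells (Homo sapiens) for antiproliferative activity, read by propidium iodide staining, with a stated time of 96 h (on this read-out lower numbers stand for stronger inhibition and higher numbers for weaker inhibition), compound 2 gives 26300 nM, the higher of the two numbers, which makes it the weaker inhibitor of the pair. Compound 3 `CC(O)(COc1ccc(C#N)cc1C(F)(F)F)C(=O)Nc1cccc(S(F)(F)(F)(F)F)c1` alters compound 2 in one place: cyano in place of hydrogen on an aromatic carbon. This is cyano in place of hydrogen on an aromatic carbon, para to a large group.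

Among the compounds with values here, one measured step bears on this: a 2.7-fold higher number from compound 1 to compound 2 (0.44 log units; beyond the scatter), with 2-(trifluoromethyl)phenyl in place of 4-(trifluoromethyl)phenyl. Compound 3 keeps the trifluoromethyl group of compound 2 and also fills the place that compound 1 fills, though with a different group. Within the data shown here, no measured compound carries cyano, so the expectation is loose: a modest step towards a lower number in this assay. The estimate is a 2.6-fold lower number from compound 2 to compound 3 (0.42 log units; beyond the scatter). Compound 3 is expected at 10000 nM, within an estimated range of 3000 nM to 30000 nM.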

Compound 3, half-maximal inhibitory concentration: 16400 nM
For compound 3 the middle estimate is 1.6-fold (0.21 log units) below the measured one; the measured number falls inside the stated range.
By their numbers in this assay, from the lowest: compounds 1, 3 and 2 (each within the scatter of the next, the first and the last beyond it).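

In this assay, cyano in place of hydrogen gives a 1.6-fold lower number from compound 2 to compound 3 (0.21 log units; within the scatter). This step lies within the scatter, so this one change, on an aromatic carbon meta to a trifluoromethyl group and para to a large group, cannot be told apart from no change in this assay. Within the data shown here, until now only the place of the trifluoromethyl group had been varied, and compound 3 is the first to show a new group added to the ring while that trifluoromethyl group stays. No measurement at hand offers an explanation for this result.

From the compounds shown here alone, whether an amine or a carboxylic acid at this same place would give a step beyond the scatter stays open. So does what cyano would do on a ring without the trifluoromethyl group.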